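The source may hold more compounds than are shown below. What is called first, only, known or untested is meant among the compounds shown, and "the series" means these compounds.

Three compounds share one core and differ only in the aromatic ring attached to the carbonyl carbon of the amide. Compound 1 `CCCCCCCCCCCC[C@@H](O)[C@H]1CC[C@H]([C@H](O)CCCCCCCCCCNC(=O)c2ccsc2)O1` gives 3020 nM in a functional assay on BSY-1 cells (Homo sapiens) for inhibition, read by colorimetric assay and sulforhodamine B assay, with a stated time of 48 h; on this read-out higher numbers stand for weaker inhibition of growth and lower numbers for stronger inhibition of growth. Compound 2 `CCCCCCCCCCCC[C@@H](O)[C@H]1CC[C@H]([C@H](O)CCCCCCCCCCNC(=O)c2ccnn2C)O1` gives 10 nM in this assay, and compound 3 `CCCCCCCCCCCC[C@@H](O)[C@H]1CC[C@H]([C@H](O)CCCCCCCCCCNC(=O)c2cccs2)O1` gives 18200 nM in this assay. On these numbers compound 3 stands highest, the weakest inhibitor of growth of the three: the step of a 6.0-fold higher number from compound 1 to compound 3 (0.78 log units; beyond the scatter) is modest, and the step of a 1800-fold higher number from compound 2 to compound 3 (3.26 log units; beyond the scatter) is large.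

Compound 4 `CCCCCCCCCCCC[C@@H](O)[C@H]1CC[C@H]([C@H](O)CCCCCCCCCCNC(=O)c2ccco2)O1` is the next variation, in which (furan-2-yl in place of thiophen-2-yl on a carbonyl carbon). Among the measured compounds shown here, no measured pair makes this exact exchange. The two steps that bear on it both alter the ring on the same carbonyl carbon. Moving from one thiophene ring to the other, a 6.0-fold higher number from compound 1 to compound 3 (0.78 log units; beyond the scatter), shifted the number only modestly, whereas moving from the 1-methyl-1H-pyrazol-5-yl ring, a 1800-fold higher number from compound 2 to compound 3 (3.26 log units; beyond the scatter), was large. Compound 4 keeps a five-membered aromatic ring with one hetero atom, as in compound 3, so only a modest step is expected, and its direction is uncertain. Compound 4 is therefore estimated at 12000 nM, with a likely range of 3000 nM to 45000 nM. This estimate means an expected step of a 1.5-fold lower number from compound 3 to compound 4 (0.18 log units; within the scatter), close to the usual scatter.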

Compound 4, concentration for 50% growth inhibition: 490 nM
Compound 4: middle estimate off by 24-fold (1.39 log units), on the high side; measured number below the stated range.
By their numbers in this assay, from the lowest: compound 2; then compound 4; then compound 1; then compound 3.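

In this assay, the exchange of thiophen-2-yl for furan-2-yl on the carbonyl carbon gives a 37-fold lower number from compound 3 to compound 4 (1.57 log units; beyond the scatter), so this position responds strongly even when the ring size, the count of hetero atoms and the count of hydrogen-bond acceptors all stay the same, and only sulfur becomes oxygen. The furan-2-yl ring also improves on the other thiophene, with a 6.2-fold lower number from compound 1 to compound 4 (0.79 log units; beyond the scatter), yet it does not match the 1-methyl-1H-pyrazol-5-yl ring, as shown by a 49-fold higher number from compound 2 to compound 4 (1.69 log units; beyond the scatter), which places the furan-2-yl amide in the middle of this small set rather than at either end. No measurement here explains why oxygen and sulfur differ so much at this position.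

Going by these compounds, it remains open whether furan-3-yl would keep this gain, which would show whether the point of attachment matters in the furan as it does in the thiophenes. A 1H-pyrazol-5-yl ring without the methyl group would show how much of the low number of compound 2 depends on that methyl.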